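This account rests on a few compounds, and the source may have more. Where it says the series, first, only, none or still open, it means among the compounds named here.

Compound 3 `O=c1[nH]cc(S(=O)(=O)Nc2ccc(-c3cn(-c4ccccc4)nn3)cc2)c(=O)[nH]1` shares its core with compound 1 `O=c1[nH]cc(S(=O)(=O)Nc2ccccc2-c2cn(-c3ccccc3)nn2)c(=O)[nH]1`; the two differ only in where the triazole-bearing arm sits on the sulfonamide-bearing ring. In a functional assay on OVCAR-3 cells (Homo sapiens) for antiproliferative activity, read by MTT assay, with a stated time of 24 h (on this read-out lower numbers stand for stronger inhibition and higher numbers for weaker inhibition), compound 1 gives 6650 nM, and compound 3 gives 18000 nM, the highest of the two plain numbers shown, with compound 1 as the nearest neighbour at a lower value. Compound 2 `O=c1[nH]cc(S(=O)(=O)Nc2ccccc2-c2cn(-c3cccc(F)c3)nn2)c(=O)[nH]1` is reported in this assay only as a limit, > 20000 nM, as noted in the limit of > 20000 nM in this assay, at which 1 of the 3 values shown sits. Within the data shown here, the one measured step that alters the outer phenyl ring, an at least 3.0-fold higher number from compound 1 to compound 2 (0.47 log units; beyond the scatter), runs toward weaker inhibition.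

Compound 4 `Cc1ccc(-n2cc(-c3ccc(NS(=O)(=O)c4c[nH]c(=O)[nH]c4=O)cc3)nn2)cc1` differs from compound 3 by methyl in place of hydrogen on an aromatic carbon. Among the measured compounds shown here, this change also sits on the outer phenyl ring, and no measured step covers a methyl there. Because an at least 3.0-fold higher number from compound 1 to compound 2 (0.47 log units; beyond the scatter) went toward weaker inhibition after substitution on that ring, compound 4 is expected to show a 1.4-fold higher number from compound 3 to compound 4 (0.14 log units; within the scatter), a modest rise or none beyond the scatter. Compound 4 is therefore estimated at 25000 nM, with a range from 12000 nM to 60000 nM, and a fair chance that this assay reports only a limit.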

Compound 4, half-maximal inhibitory concentration: 5630 nM
The estimate for compound 4 lay 4.4-fold (0.65 log units) above the measured number; the whole stated range lies above it.
By their numbers in this assay, from the lowest: compounds 4 and 1 (each within the scatter of the next); then compound 3. At a limit, above all of these: compound 2.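

In this assay, phenyl to 4-methylphenyl, para to a large group, gives a 3.2-fold lower number from compound 3 to compound 4 (0.50 log units; beyond the scatter), so substitution on the outer phenyl ring does not always run toward weaker inhibition. This direction is opposite to that of an at least 3.0-fold higher number from compound 1 to compound 2 (0.47 log units; beyond the scatter), but that step carries fluoro rather than methyl, at a different ring carbon and with the triazole-bearing arm elsewhere on the sulfonamide-bearing ring, so the two steps cannot be read as one effect of substitution. Compound 2 stays a limit and not a number: the limit of > 20000 nM in this assay, at which 1 of the 4 values shown sits.

As far as these compounds go, whether this step is particular to methyl remains open, and an ethyl group, an amine or a carboxylic acid at the same place would test that. Also open, from the compounds shown here alone, is what the same methyl does on the outer ring of compound 1.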